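Pyridin-2-yl for Phenyl in the Ether Arm

The source may hold more compounds than are shown below. What is called first, only, known or untested is meant among the compounds shown, and "the series" means these compounds.

Compound 2 `O=C(COCc1ccccc1)N1CCN(c2ccc(Cl)cc2Cl)CC1` gives 1000 nM in a functional assay on HEK293 cells for positive allosteric modulation of metabotropic glutamate receptor 5 (Homo sapiens), read by FLIPR and calcium flux (a lower number here means that less compound is needed, a higher number that more compound is needed for the effect), the second highest of the three numbers measured. Compound 1 `O=C(COCc1ccccc1)N1CCN(c2cccc(Cl)c2)CC1` gives 6700 nM, and compound 3 `O=C(COCc1ccccc1)N1CCN(c2cc(Cl)ccn2)CC1` gives 570 nM. The steps of a 6.7-fold lower number from compound 1 to compound 2 (0.83 log units; beyond the scatter) and a 12-fold lower number from compound 1 to compound 3 (1.07 log units; beyond the scatter) lie beyond the scatter, while a 1.8-fold lower number from compound 2 to compound 3 (0.24 log units; within the scatter) lies within it. Compound 4 `O=C(COCc1ccccn1)N1CCN(c2ccc(Cl)cc2Cl)CC1` differs from compound 2 by pyridin-2-yl in place of phenyl on a saturated chain carbon bound to an oxygen on a saturated carbon. Among the compounds with values here, none of the measured steps touches this part of the molecule; all three alter the group on the amine nitrogen in the ring. The only loose hint is the step from compound 2 to compound 3, where a ring nitrogen entered elsewhere and the number stayed within the scatter. Compound 4 is therefore expected to show no change at the digits printed from compound 2 to compound 4 (within the scatter), nothing beyond the scatter. The estimate for compound 4 is 1000 nM, between 350 nM and 3000 nM.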

Compound 4, half-maximal effective concentration: 310 nM
Compound 4: middle estimate off by 3.2-fold (0.51 log units), on the high side; the whole stated range lies above it.
By their numbers in this assay, from the lowest: compounds 4, 3 and 2 (each within the scatter of the next, the first and the last beyond it); then compound 1.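

Pyridin-2-yl in place of phenyl on a saturated chain carbon bound to an oxygen on a saturated carbon gives a 3.2-fold lower number from compound 2 to compound 4 (0.51 log units; beyond the scatter) in this assay, so this arm, which the earlier compounds left unchanged, can also move the number beyond the scatter. No measurement available here accounts for this step.

As far as these compounds go, whether pyridin-3-yl or pyridin-4-yl would do the same remains open, as does the effect of an amine on this arm. Also open, from the compounds shown here alone, is whether the step holds with the 4-chloropyridin-2-yl group of compound 3 on the amine nitrogen.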